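The source may report more compounds than this note shows. Statements on the series, on what has been measured and on what is new or still open speak of the compounds shown alone.

In a functional assay on U-251 cells (Homo sapiens) for antiproliferative activity, read by sulforhodamine B assay, with a stated time of 48 h, tested at 50 uM (on this read-out lower numbers stand for less inhibition and higher numbers for more inhibition at the one concentration tested (going by the name of the read-out)), compound 1 `COc1ccc(C(=O)Oc2cc3c(cc2C)[C@@H](C(C)C)CC=C3C)cc1` gives 37% and compound 2 `COc1ccc(C(=O)Oc2cc3c(C)ccc(C(C)C)c3cc2C)cc1` gives 42.6%. Compound 3 `Cc1cc2c(C(C)C)ccc(C)c2cc1OC(=O)c1ccc(C(F)(F)F)cc1` gives 16.5%, the lowest of the three numbers, with compound 1 standing nearer to it than compound 2. For the measured compounds named here, the single step recorded between measured compounds, a number 26.1 percentage points lower from compound 2 to compound 3 (beyond the scatter), is a modest drop that lies beyond the scatter. Compound 4 `Cc1cc2c(C(C)C)ccc(C)c2cc1OC(=O)c1ccc([N+](=O)[O-])cc1` differs from compound 3 by nitro in place of trifluoromethyl on an aromatic carbon. Going by the values given here, no measured step covers a nitro group, so the only guide is that exchanging the group on that aromatic carbon shifted this assay by a modest amount once. A small rise is therefore expected, a number 8.5 percentage points higher from compound 3 to compound 4 (within the scatter), though a step within the scatter cannot be excluded. For compound 4 the expected value is 25%, estimated to fall between 8% and 48%.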

Compound 4, a percentage reported as inhibition, at one concentration (the size of the read-out at that concentration, not a potency): 100%
Estimate against measurement, compound 4: 75 percentage points below; measured number outside the range, above it.
By their numbers in this assay, from the lowest: compound 3; then compounds 1 and 2 (each within the scatter of the next); then compound 4.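

For the compounds shown here, on the aromatic carbon para to a large group, the substituent matters far more in this assay than the earlier compounds showed: nitro in place of trifluoromethyl gives a number 83.5 percentage points higher from compound 3 to compound 4 (beyond the scatter), and nitro in place of methoxy gives a number 57.4 percentage points higher from compound 2 to compound 4 (beyond the scatter). Going by these compounds alone, both steps are large, whereas the one earlier change here was modest, so this position is not confined to modest shifts. Nothing at hand accounts for the nitro result.

On these data alone, whether the high number is specific to nitro stays open; an amine or a nitrile on the same aromatic carbon would test this. Also open, as far as these compounds go, is whether nitro has the same effect on the core of compound 1.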